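The source may hold more compounds than are shown below. What is called first, only, known or untested is meant among the compounds shown, and "the series" means these compounds.

Working notes on the series. In a functional assay on PANC-1 cells (Homo sapiens) for inhibition, read by XTT assay, with a stated time of 72 h (on this read-out higher numbers stand for weaker inhibition and lower numbers for stronger inhibition), compound 1 (`CC(C)(C)OC(=O)N1CCC[C@H]1COCCCCCC/C=C/c1ccc(Oc2ccccc2)cc1`) gives 63300 nM and compound 2 (`O=CN1CCC[C@H]1COCCCCCC/C=C/c1ccc(-c2ccccc2)cc1`) gives 50000 nM. These two values lie within the scatter of each other, so compound 2 stands level with compound 1 and no order can be drawn between them. Both numbers are high on this read-out, which marks weak inhibition.

The next compound to be measured is compound 3 (`O=CN1CCC[C@H]1COCCCCCC/C=C/c1ccc(Oc2ccccc2)cc1`). Compared with compound 2, it has phenoxy in place of phenyl on an aromatic carbon of the six-membered aromatic ring, para to a large group: phenoxy in place of phenyl on an aromatic carbon.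

Among the measured compounds shown here, the series holds no measured step that differs in one place, so nothing shows directly what this exchange does in this assay. Phenoxy also occurs in compound 1, which gives 63300 nM, and this is the only guide to the new group. No step beyond the scatter is expected in either direction. The estimated step is a 1.1-fold higher number from compound 2 to compound 3 (0.04 log units; within the scatter), expected to stay within the scatter. For compound 3 the estimated value is 55000 nM, with an expected range of 27000 nM to 100000 nM.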

Compound 3, half-maximal inhibitory concentration: 53300 nM
Beside the measured number, compound 3's estimate is 1.0-fold (0.01 log units) above it, within the range that was stated.
By their numbers in this assay, from the lowest: compounds 2, 3 and 1 (each within the scatter of the next).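

Compound 3 gives the series its first steps that differ in one place. In this assay, phenoxy in place of phenyl on an aromatic carbon, para to a large group, gives a 1.1-fold higher number from compound 2 to compound 3 (0.03 log units; within the scatter), so on this pair the added oxygen and its hydrogen-bond acceptor leave the number level with that of the phenyl compound. Hydrogen in place of tert-butoxy on a carbonyl carbon gives a 1.2-fold lower number from compound 1 to compound 3 (0.07 log units; within the scatter), which shows that this second place also yields no step beyond the scatter, something the two earlier compounds could not show as they differ in two places. No measurement here bears on the reason for either result.

Each exchange rests on a single pair, and all three numbers remain high on this read-out, so neither place has yet produced a step that can be ordered. From the compounds shown here alone, whether an amine or a carboxylic acid on that aromatic carbon, a group other than hydrogen or tert-butoxy on the carbonyl carbon, or a longer chain in the shared core would move the number beyond the scatter remains open.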